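Adding a chloro group to compound 1

The compounds below may be only part of what the source reports. "The series", "measured", "known", "first", "only" and "open" are said of these compounds alone.

Measured in an ADME assay on microsomes from liver (Rattus norvegicus) for metabolic stability, read by LC-MS, using NADPH, at 37 degrees C; on this read-out lower numbers stand for a shorter-lived compound and higher numbers for a longer-lived compound:
- Compound 1 `Cc1ccccc1-c1nc(CN2CCC(C(=O)NCCCN3CCC(C(C)C)CC3)CC2)c(C)o1`: 0.147 h
- Compound 2 `Cc1ccccc1-c1nc(CN2CCC(C(=O)NCCCN3CCC(C)(C)CC3)CC2)c(C)o1`: > 0.5 h
- Compound 3 `Cc1ccccc1-c1nc(CN2CCC(C(=O)NCCCN3CC4CCCC(C4)C3)CC2)c(C)o1`: 0.123 h

Compound 1 and compound 3 lie within the scatter of each other: a 1.2-fold lower number from compound 1 to compound 3 (0.08 log units; within the scatter). Compound 2 gives only a limit of the assay, > 0.5 h.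

Compound 4 `Cc1cccc(Cl)c1-c1nc(CN2CCC(C(=O)NCCCN3CCC(C(C)C)CC3)CC2)c(C)o1` differs from compound 1 on the aromatic ring: chloro in place of hydrogen on an aromatic carbon. Thus 2-methylphenyl becomes 2-chloro-6-methylphenyl. The measured steps change only the group on the saturated chain, as in an at least 3.4-fold higher number from compound 1 to compound 2 (0.53 log units; beyond the scatter), so none measures this change directly. No step beyond the scatter is therefore expected from compound 1. Compound 1 gives 0.147 h. The expected step is a 1.1-fold lower number from compound 1 to compound 4 (0.02 log units; within the scatter). For compound 4 the estimate is 0.14 h, with an expected range of 0.06 h to 0.33 h.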

Compound 4, half-life: 0.0333 h
Compound 4: middle estimate off by 4.2-fold (0.62 log units), on the high side, and the stated range ends above it.
By their numbers in this assay, from the lowest: compound 4; then compounds 3 and 1 (each within the scatter of the next). At a limit, above all of these: compound 2.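

The earlier compounds shown here differ only in the group on the saturated chain, so they say nothing about the aromatic ring. In this assay, this ring proves sensitive to a single added atom: chloro in place of hydrogen, turning 2-methylphenyl into 2-chloro-6-methylphenyl, shortens the half-life (a 4.4-fold lower number from compound 1 to compound 4 (0.64 log units; beyond the scatter)). Nothing measured here explains why.

As far as these compounds go, whether fluoro or methoxy on this aromatic carbon would shorten it likewise remains open. So does whether chloro has the same effect alongside the 4,4-dimethylpiperidin-1-yl group of compound 2.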